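This account rests on a few compounds, and the source may have more. Where it says the series, first, only, none or still open, it means among the compounds named here.

Compound 1 `CNC(=O)c1cc(Oc2ccc(NC(=O)c3cc4cccnc4n(-c4ccccc4F)c3=O)cc2)ccn1` was examined in a functional assay on U-87MG ATCC cells for antiproliferative activity against U-87 MG (Homo sapiens), read by MTT assay, with a stated time of 72 h (a lower number here means a stronger inhibitor, a higher number a weaker inhibitor), where compound 1 gives 3360 nM. Compound 2 `CNC(=O)c1cc(Oc2ccc(NC(=O)c3cc4cccnc4n(-c4ccc(F)cc4)c3=O)cc2)ccn1` carries 4-fluorophenyl in place of 2-fluorophenyl on an aromatic nitrogen; in this assay compound 2 gives 2910 nM, so that a 1.2-fold lower number from compound 1 to compound 2 (0.06 log units; within the scatter). Compound 3 `CCCNC(=O)c1cc(Oc2ccc(NC(=O)c3cc4cccnc4n(-c4ccccc4F)c3=O)cc2)ccn1` differs from compound 1, and hence its core from the shared core of compound 1 and compound 2, by ethyl in place of hydrogen on a saturated chain carbon bound to an amide-type nitrogen; in this assay compound 3 gives 2320 nM, which amounts to a 1.4-fold lower number from compound 1 to compound 3 (0.16 log units; within the scatter). Compound 4 `CCCNC(=O)c1cc(Oc2ccc(NC(=O)c3cc4cccnc4n(-c4ccc(F)cc4)c3=O)cc2)ccn1` has not yet been measured in this assay. It differs from compound 3 by 4-fluorophenyl in place of 2-fluorophenyl on an aromatic nitrogen, the same change as that from compound 1 to compound 2, at a place described in identical words. The step of a 1.2-fold lower number from compound 3 to compound 4 (0.06 log units; within the scatter) is expected to be small, since the same change gave a 1.2-fold lower number from compound 1 to compound 2 (0.06 log units; within the scatter). Compound 4 is therefore estimated at 2000 nM, most likely between 900 nM and 4500 nM.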

Compound 4, half-maximal inhibitory concentration: 960 nM
Compound 4: middle estimate off by 2.1-fold (0.32 log units), on the high side; the measured number falls inside the stated range.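

In this assay, 4-fluorophenyl in place of 2-fluorophenyl gives a 2.4-fold lower number from compound 3 to compound 4 (0.38 log units; beyond the scatter), and this step does not separate measurably from the one on the other core: the same change on two cores in this assay, a 1.2-fold lower number (0.06 log units; within the scatter) from compound 1 to compound 2 and a 2.4-fold lower number (0.38 log units; beyond the scatter) from compound 3 to compound 4, 2.1-fold (0.32 log units) apart, within the scatter of two such steps. Ethyl in place of hydrogen on the chain carbon gives a 3.0-fold lower number from compound 2 to compound 4 (0.48 log units; beyond the scatter), and it too stays close to its earlier counterpart: the same change on two cores in this assay, a 1.4-fold lower number (0.16 log units; within the scatter) from compound 1 to compound 3 and a 3.0-fold lower number (0.48 log units; beyond the scatter) from compound 2 to compound 4, 2.1-fold (0.32 log units) apart, within the scatter of two such steps. Each change thus carries across these two cores without a gap beyond the scatter, but each step passes the scatter on one core only, and a single set of four compounds does not establish a general rule for the series.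

The compounds shown leave open whether a phenyl without fluorine on the aromatic nitrogen would behave alike. They also leave open how a longer chain on the amide-type nitrogen would behave.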